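The source may hold more compounds than are shown below. What is called first, only, known or untested is meant among the compounds shown, and "the series" means these compounds.

Of the compounds shown here, two built on a shared core have been tested in a functional assay on HCT-116 cells (Homo sapiens) for cytotoxicity, read by MTT assay, with a stated time of 48 h; on this read-out lower numbers stand for stronger inhibition and higher numbers for weaker inhibition. Compound 1 `Cc1nc2c3ccccc3ccc2c2nc3c(ccc4ccccc43)c(-c3cccc4ccccc34)c12` gives 20800 nM in this assay, and compound 2 `Cc1nc2c3ccccc3ccc2c2nc3c(ccc4ccccc43)c(-c3ccccc3N)c12` gives 4760 nM. Going by the values given here, compound 2 therefore holds the lower of the two numbers, and the only measured step, a 4.4-fold lower number from compound 1 to compound 2 (0.64 log units; beyond the scatter), separates it from compound 1. Compound 3 `Cc1nc2c3ccccc3ccc2c2nc3c(ccc4ccccc43)c(C)c12` awaits measurement. It differs from compound 2 in one place: methyl in place of 2-aminophenyl on an aromatic carbon. Among the compounds with values here, the single measured step swapped one aromatic group for another at this same place, whereas here the aromatic group is removed altogether, so that step gives only rough guidance. The group that leaves carries a hydrogen-bond donor and the methyl that enters carries none. The number for compound 3 is expected to rise, giving a 2.5-fold higher number from compound 2 to compound 3 (0.40 log units; beyond the scatter) in this assay. The estimate for compound 3 is 12000 nM, within a range from 4000 nM to 40000 nM.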

Compound 3, half-maximal inhibitory concentration: > 80000 nM
Compound 3 ended at the assay's limit (the forecaster's own chance of this, stated with the estimate: 15%); middle value at least 6.6-fold (0.82 log units) from the limit.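

Compound 3 stands at a limit of this assay and not at a true number: the limit of > 80000 nM in this assay, at which 1 of the 3 values shown sits. Putting methyl in place of 2-aminophenyl gives an at least 16-fold higher number from compound 2 to compound 3 (1.22 log units; beyond the scatter), and putting methyl in place of naphthalen-1-yl gives an at least 3.8-fold higher number from compound 1 to compound 3 (0.58 log units; beyond the scatter). The earlier step only compared two aromatic groups at this aromatic carbon, whereas these steps show that both compounds with an aromatic ring here give lower numbers than the compound with methyl, so the choice of group at this place can move the read-out a long way.

Still open, as far as these compounds go, is how much of this rests on the ring alone and how much on its amine, a question a plain phenyl group at this place would address. Equally open, from the compounds shown here alone, is whether the ring must be aromatic, which a cyclohexyl group would bear on.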